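From amide to ester at the carbonyl of compound 3

The source may report more compounds than this note shows. Statements on the series, on what has been measured and on what is new or still open speak of the compounds shown alone.

Of the compounds shown here, three sharing one core have been measured in an assay on membranes from CHO cells for displacement of a labelled ligand from adenosine receptor A1 (Homo sapiens), read by scintillation counting, with a stated time of 60 min, tested at 1 uM; a higher number here means more inhibition at the concentration tested (going by the name of the read-out), a lower number less inhibition. Compound 1 `CC1=C(C(=O)CC(C)C)C(c2ccsc2)NC(=O)N1` gives 37%. Compound 2 `CCNC(=O)C1=C(C)NC(=O)NC1c1ccsc1` gives 3%, and compound 3 `CCN(CC)C(=O)C1=C(C)NC(=O)NC1c1ccsc1` gives 11%. Compound 3 stands second highest of the three: its number is close to that of compound 2, since a number 8 percentage points higher from compound 2 to compound 3 (within the scatter), while the gap to compound 1 is real, as a number 26 percentage points lower from compound 1 to compound 3 (beyond the scatter). Compound 4 `CC1=C(C(=O)OC2CCC2)C(c2ccsc2)NC(=O)N1` has not been measured. It differs from compound 3 at a carbonyl carbon: cyclobutyloxy in place of diethylamino on a carbonyl carbon. Among the measured compounds shown here, the steps that bear on this are those that change the group on the same carbonyl carbon: a number 34 percentage points lower from compound 1 to compound 2 (beyond the scatter) and a number 26 percentage points lower from compound 1 to compound 3 (beyond the scatter), both moves from isobutyl to an amide-type nitrogen that lowered the number beyond the scatter. Replacing diethylamino with cyclobutyloxy removes the nitrogen again, so compound 4 is expected to recover part of that loss, a number 13 percentage points higher from compound 3 to compound 4 (beyond the scatter), though with wide uncertainty. In this assay compound 4 is estimated at 24%, within 6% to 42%.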

Compound 4, a percentage reported as inhibition, at one concentration (the size of the read-out at that concentration, not a potency): 40%
Compound 4: middle estimate off by 16 percentage points, on the low side; the range from low to high includes it.
By their numbers in this assay, from the lowest: compounds 2 and 3 (each within the scatter of the next); then compounds 1 and 4 (each within the scatter of the next).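

In this assay, replacing either nitrogen group on the carbonyl carbon with cyclobutyloxy raises the number, with the step from the diethylamino compound reading (a number 29 percentage points higher from compound 3 to compound 4 (beyond the scatter)) and the step from the ethylamino compound reading (a number 37 percentage points higher from compound 2 to compound 4 (beyond the scatter)). Against the isobutyl group, the same position shows no separation (a number 3 percentage points higher from compound 1 to compound 4 (within the scatter)), so among these four compounds the two with nitrogen on this carbonyl carbon sit low and the two without it sit higher, with none going against that split. Nothing measured here gives a reason for these shifts.

Cyclobutyloxy brings both an oxygen and a ring, so its two parts remain unseparated. An open-chain butyloxy group would test the ring's share, while cyclobutylamino would test whether the nitrogen still lowers the number with the ring in place.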